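The source may hold more compounds than are shown below. What is called first, only, known or untested is meant among the compounds shown, and "the series" means these compounds.

Working notes on the series. The shared core is that of compound 1 `O=C1C2=C(C(=O)c3ncccc31)C1(CS2)NC(=O)N(c2ccc(Cl)cc2)C1=O`, which in a functional assay on XF498 cells (Homo sapiens) for antiproliferative activity, read by MTT assay, with a stated time of 96 h (a lower number here means a stronger inhibitor, a higher number a weaker inhibitor), gives 590 nM, the lowest of the three numbers in hand. Compound 2 `CCN(CC)c1ccc(N2C(=O)NC3(CSC4=C3C(=O)c3ncccc3C4=O)C2=O)cc1` gives 730 nM in this assay, and the step of a 1.2-fold higher number from compound 1 to compound 2 (0.09 log units; within the scatter) stays within the scatter, so the two cannot be ranked against each other. Going by the values given here, compound 3 `O=C1NNC(=O)C2(CSC3=C2C(=O)c2ncccc2C3=O)N1` gives 5000 nM in this assay; no single-point step joins it to compound 1, and the two values simply stand well apart.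

Compound 4 `CCCCc1ccc(N2C(=O)NC3(CSC4=C3C(=O)c3ncccc3C4=O)C2=O)cc1` has not yet been measured. It differs from compound 1 by butyl in place of chloro on an aromatic carbon. Among the compounds with values here, the only measured step that bears on this change is a 1.2-fold higher number from compound 1 to compound 2 (0.09 log units; within the scatter), which also exchanges the group on that same aromatic carbon and lies within the scatter. On that basis no step beyond the scatter is expected in this assay, and the expected move is a 1.2-fold higher number from compound 1 to compound 4 (0.07 log units; within the scatter). Compound 4 is therefore estimated at 700 nM, with a range from 300 nM to 1700 nM.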

Compound 4, half-maximal inhibitory concentration: 950 nM
Compound 4: the middle estimate sits 1.4-fold (0.13 log units) below what was measured; measured number inside the range.
By their numbers in this assay, from the lowest: compounds 1, 2 and 4 (each within the scatter of the next); then compound 3.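

On the aromatic carbon para to a large group, butyl in place of chloro gives a 1.6-fold higher number from compound 1 to compound 4 (0.21 log units; within the scatter), and butyl in place of diethylamino gives a 1.3-fold higher number from compound 2 to compound 4 (0.11 log units; within the scatter), so compounds 1, 2 and 4 cannot be ranked against one another in this assay. The earlier compounds shown here offered a single exchange here; there are now three groups at this position with all steps among them within the scatter, including the change from chloro with 1 heavy atom to butyl with 4 heavy atoms. No supporting data are available to explain these results.

On these data alone, whether a carboxylic acid, a hydroxyl or a chain longer than butyl on this carbon would also stay within the scatter remains open. Compound 3 differs from the others in more than one place, so its separate standing cannot be traced to any single change.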